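This account rests on a few compounds, and the source may have more. Where it says the series, first, only, none or still open, it means among the compounds named here.

Series notes. Compound 1 `Cc1c(OCCCCOc2ccccc2F)ccc(C(=O)CC(C)C)c1O` carries a 2-fluorophenoxy group on a saturated chain carbon, four bonds along the chain from an oxygen on an aromatic ring; in a functional assay for binding affinity to metabotropic glutamate receptor 2 (Homo sapiens), read by GTPgammaS binding (a lower number here means that less compound is needed, a higher number that more compound is needed for the effect), compound 1 gives 1990 nM. Within the data shown here, compound 2 `CC(C)CC(=O)c1ccc(OCCCCOc2ccccc2)c(Br)c1O`, the only other member measured, gives in this assay 1500 nM. The two numbers lie within the usual scatter of each other, so compound 1 is not set apart from compound 2 on this read-out. Compound 3 `Cc1c(OCCCCSc2cccnc2)ccc(C(=O)CC(C)C)c1O` has not been measured. It differs from compound 1 by one change: (pyridin-3-yl)sulfanyl in place of 2-fluorophenoxy on a saturated chain carbon, four bonds along the chain from an oxygen on an aromatic ring. Among the measured compounds shown here, no measured pair in the set carries this change, and no step between measured compounds is available, so nothing here says how the half-maximal effective concentration moves with such a change. The expectation for compound 3 is a step of about a 1.3-fold higher number from compound 1 to compound 3 (0.10 log units; within the scatter) in this assay, no larger than the scatter. On that basis compound 3 is estimated at 2500 nM, with a range from 900 nM to 7000 nM.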

Compound 3, half-maximal effective concentration: 1090 nM
For compound 3 the middle estimate is 2.3-fold (0.36 log units) above the measured one; the range from low to high includes it.
By their numbers in this assay, from the lowest: compounds 3, 2 and 1 (each within the scatter of the next).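

Working notes: in this assay, (pyridin-3-yl)sulfanyl in place of 2-fluorophenoxy on a saturated chain carbon, four bonds along the chain from an oxygen on an aromatic ring, gives a 1.8-fold lower number from compound 1 to compound 3 (0.26 log units; within the scatter) and is the first step in the series that isolates one place. This position therefore accepts a combined exchange of the linking oxygen for sulfur and the fluorinated carbon ring for a ring with one hetero atom, with no shift beyond the scatter on this read-out. No other measurement is available that bears on this result.

Among these compounds, the single step cannot separate the contributions of the sulfur, the ring nitrogen and the loss of fluorine. From the compounds shown here alone, whether an amine, a carboxylic acid or a longer chain at this place would move the number beyond the scatter remains open.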